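A few compounds are considered here, and "the series" means these few. Any claim that something is new, unique, unknown or untested is made for them only; others in the source may bear on it.

Three compounds have been measured in an assay on HEK293 cells for antagonist activity at P2X purinoceptor 7 (Homo sapiens), read by fluorescence, with a stated time of 2 h; a lower number here means a stronger inhibitor, a higher number a weaker inhibitor:

compound 1 `O=C(c1ccc(Cl)c(C(F)(F)F)c1)N1CCC(n2cncc2-c2ccc(OS(=O)(=O)c3cccc(Br)c3)cc2)CC1` gives 896 nM
compound 2 `O=C(NC1CC1)c1cccc(S(=O)(=O)Oc2ccc(-c3cncn3C3CCN(C(=O)c4ccc(Cl)c(C(F)(F)F)c4)CC3)cc2)c1` gives 88 nM
compound 3 `CS(=O)(=O)c1ccc(C(=O)N2CCC(n3cncc3-c3ccc(OS(=O)(=O)c4cccc5cnccc45)cc3)CC2)cc1` gives 25 nM

Compound 3 holds the lowest number of the three, which in this assay means the strongest inhibition seen so far. Compound 2 stands nearest to it and compound 1 furthest, and both gaps lie beyond the usual scatter of repeated measurements. Going by the values given here, the only step between two measured compounds that differ in a single place is a 10-fold lower number from compound 1 to compound 2 (1.01 log units; beyond the scatter), and that change sits on a different part of the molecule from the one at issue here.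

Compound 4 `CCN(CC)c1ccc(C(=O)N2CCC(n3cncc3-c3ccc(OS(=O)(=O)c4cccc5cnccc45)cc3)CC2)cc1` differs from compound 3 in one place: diethylamino in place of methylsulfonyl on an aromatic carbon. Among the compounds with values here, no measured step touches the ring where this change falls, so neither the size nor the direction of its effect can be read from the numbers at hand. In the absence of any such step, a modest change is expected, a 2.4-fold higher number from compound 3 to compound 4 (0.38 log units; beyond the scatter). Compound 4 is therefore estimated at 60 nM, within a range from 15 nM to 250 nM.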

Compound 4, half-maximal inhibitory concentration: 1440 nM
Beside the measured number, compound 4's estimate is 24-fold (1.38 log units) below it; measured number outside the range, above it.
By their numbers in this assay, from the lowest: compound 3; then compound 2; then compounds 1 and 4 (each within the scatter of the next).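

The group on this aromatic carbon, para to a large group, matters greatly: putting diethylamino in place of methylsulfonyl gives a 58-fold higher number from compound 3 to compound 4 (1.76 log units; beyond the scatter). The rest of the two structures is identical. The earlier compounds shown here offered no measured step at this position. Nothing available explains why the exchange has such a large effect.

With only these two groups compared here, the numbers cannot show whether methylsulfonyl helps, diethylamino harms, or both are true. A bare hydrogen, a nitrile or a dimethylamino group on the same carbon, with the rest of compound 3 unchanged, would help separate these possibilities and show how the number changes with the group at this position.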